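This account rests on a few compounds, and the source may have more. Where it says the series, first, only, none or still open, it means among the compounds named here.

- compound 1 `COc1ccc(C(=O)CCN2CCN(c3ccc(Cl)cc3)CC2)cc1`: 300000 nM
- compound 2 `O=C(CCN1CCN(c2ccc(F)cc2)CC1)c1ccc(F)c(Cl)c1`: 185000 nM
- compound 3 `O=C(CCN1CCN(c2ccc(C(F)(F)F)cc2)CC1)c1ccc(F)c(Cl)c1`: 74500 nM

All three numbers come from an ADME assay on Vero cells (Chlorocebus sabaeus) for cytotoxicity, read by resazurin assay, with a stated time of 72 h; a lower number here means a stronger inhibitor, a higher number a weaker inhibitor. Compound 3 has the lowest number of the three, so it stands at the most cytotoxic end of this small set.

The next compound, compound 4 `O=C(CCN1CCN(c2ccc(Cl)cc2)CC1)c1ccc(F)c(Cl)c1`, changes one group of compound 3: chloro in place of trifluoromethyl on an aromatic carbon, para to a large group (chloro in place of trifluoromethyl on an aromatic carbon).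

Within the data shown here, only one measured step changes a group at this place: a 2.5-fold lower number from compound 2 to compound 3 (0.40 log units; beyond the scatter). There, trifluoromethyl took the place of fluoro, and the step was modest. Compound 4 removes the same trifluoromethyl group, but puts chloro rather than fluoro in its place, so it does not simply return to compound 2. Compound 1 carries chloro at this place too, but differs at the other end of the molecule, so its 300000 nM offers only a loose guide.

Among the measured compounds shown here, a single step is thin evidence, and no measured pair shows directly what chloro does here. A small move towards a higher number is the most reasonable expectation, smaller than the measured step. The expected change is a 1.5-fold higher number from compound 3 to compound 4 (0.19 log units; within the scatter). For compound 4 the estimated value in this assay is 115000 nM, with an expected range of 60000 nM to 220000 nM.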

Compound 4, half-maximal inhibitory concentration: 114000 nM
Compound 4: middle estimate off by 1.0-fold (0.00 log units), on the high side, and the stated range covers the measured number.
By their numbers in this assay, from the lowest: compounds 3, 4, 2 and 1 (each within the scatter of the next, the first and the last beyond it).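

In this assay chloro and trifluoromethyl on this aromatic carbon, para to a large group, cannot be told apart, with a 1.5-fold higher number from compound 3 to compound 4 (0.18 log units; within the scatter) lying within the scatter, and chloro cannot be told apart from fluoro either, with a 1.6-fold lower number from compound 2 to compound 4 (0.21 log units; within the scatter) also lying within it. So chloro sits within the scatter of both neighbours, even though fluoro and trifluoromethyl themselves differ by more than the scatter, and the earlier step alone could not show this. Among these compounds, compound 4 also gives the first readable change on the carbonyl carbon, where 3-chloro-4-fluorophenyl replaces 4-methoxyphenyl, with a 2.6-fold lower number from compound 1 to compound 4 (0.42 log units; beyond the scatter) being modest but beyond the scatter, and no measurement here gives a reason for any of these numbers.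

Still open is how a plain hydrogen, a nitrile, an amine or a carboxylic acid on this aromatic carbon would compare with the three groups shown. Also open, on these data alone, is whether swapping 4-methoxyphenyl for 3-chloro-4-fluorophenyl would give a similar step with fluoro or trifluoromethyl in place of chloro.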